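This account rests on a few compounds, and the source may have more. Where it says the series, first, only, none or still open, it means among the compounds named here.

Notes on the series. Compound 1 `Cc1ccc(S(=O)(=O)/N=C(/CCNC2=CC(=O)c3ccccc3C2=O)Nc2ccc(Cl)cc2)cc1` and compound 2 `Cc1ccc(S(=O)(=O)/N=C(/CCNC2=CC(=O)c3ccccc3C2=O)Nc2ccc(Cl)cc2Cl)cc1` share one core; in a functional assay on DU-145 cells (Homo sapiens) for cytotoxicity, read by MTT assay, with a stated time of 48 h (on this read-out higher numbers stand for weaker inhibition and lower numbers for stronger inhibition), compound 1 gives 32400 nM and compound 2 gives 18600 nM. For the measured compounds named here, the single step between them, a 1.7-fold lower number from compound 1 to compound 2 (0.24 log units; within the scatter), is the only measured step, and it lies within the scatter. Going by the values given here, on these two numbers compound 2 stands lowest, with compound 1 its only neighbour.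

Compound 3 `COc1cc(N/C(CCNC2=CC(=O)c3ccccc3C2=O)=N\S(=O)(=O)c2ccc(C)cc2)cc(OC)c1OC` differs from compound 2 at one site: 3,4,5-trimethoxyphenyl in place of 2,4-dichlorophenyl on an amine nitrogen. Among the compounds with values here, no measured step touches an exchange of this kind; the one known step altered the aryl ring only by a single chloro and left the number within the scatter. The expectation for compound 3 in this assay is therefore no step beyond the scatter, with wide uncertainty in both directions. The estimated step is a 1.2-fold higher number from compound 2 to compound 3 (0.07 log units; within the scatter). Compound 3 is thus estimated at 22000 nM, with a range from 6000 nM to 80000 nM.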

Compound 3, half-maximal inhibitory concentration: 9330 nM
Estimate against measurement, compound 3: 2.4-fold (0.37 log units) above; low and high end bracket the measured number.
By their numbers in this assay, from the lowest: compounds 3, 2 and 1 (each within the scatter of the next, the first and the last beyond it).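

In this assay, replacing the whole aryl group on the amine nitrogen gives two readings: one stays within the scatter (a 2.0-fold lower number from compound 2 to compound 3 (0.30 log units; within the scatter)) and the other passes it (a 3.5-fold lower number from compound 1 to compound 3 (0.54 log units; beyond the scatter)). For the compounds shown here, the second is the first step beyond the scatter, so this position does respond to the aryl group, though only modestly, and 3,4,5-trimethoxyphenyl is accepted there in place of either chlorinated phenyl without a higher number. No available evidence bears on the reason for these steps.

From the compounds shown here alone, it remains open whether a single methoxy, a dimethylamino group or a carboxylic acid on the phenyl ring would give a similar number. Going by these compounds, it is also open whether the 3,4,5-trimethoxyphenyl step would hold with a longer chain to the shared core.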